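Replacing Ureido with Piperazin-1-yl on the Shared Core

The source may hold more compounds than are shown below. What is called first, only, known or untested is meant among the compounds shown, and "the series" means these compounds.

In a functional assay on SF-268 cells (Homo sapiens) for cytotoxicity, read by MTT assay, with a stated time of 3 days (on this read-out lower numbers stand for stronger inhibition and higher numbers for weaker inhibition), compound 1 `N#Cc1c(NN)nc(SCc2nc3ccccc3[nH]2)nc1-c1ccccc1` gives 2.77 nM and compound 2 `N#Cc1c(NC(N)=O)nc(SCc2nc3ccccc3[nH]2)nc1-c1ccccc1` gives 3.37 nM, so the two stand within the scatter of each other. Compound 3 `N#Cc1c(-c2ccccc2)nc(SCc2nc3ccccc3[nH]2)nc1N1CCNCC1` carries piperazin-1-yl in place of ureido on an aromatic carbon. Among the compounds with values here, no measured step covers this exchange. The nearest evidence is a 1.2-fold higher number from compound 1 to compound 2 (0.09 log units; within the scatter), a change at the same place that stayed within the scatter. The expected step, a 1.2-fold higher number from compound 2 to compound 3 (0.07 log units; within the scatter), is therefore none beyond the scatter, though with wide uncertainty. For compound 3 the estimated value is 4 nM, with an expected range of 1 nM to 20 nM.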

Compound 3, half-maximal inhibitory concentration: 20000 nM
Compound 3: middle estimate off by 5000-fold (3.70 log units), on the low side, outside the stated range (above it).
By their numbers in this assay, from the lowest: compounds 1 and 2 (each within the scatter of the next); then compound 3.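

On this aromatic carbon this assay records a 5900-fold higher number from compound 2 to compound 3 (3.77 log units; beyond the scatter) and a 7200-fold higher number from compound 1 to compound 3 (3.86 log units; beyond the scatter) when piperazin-1-yl enters. The position is therefore far from indifferent to its substituent, a sensitivity that the pair of compound 1 and compound 2, within the scatter of each other, did not reveal.

Whether the loss follows the six-membered non-aromatic ring itself or the free ring nitrogen stays open, since neither morpholin-4-yl nor an open-chain amine such as dimethylamino stands among these compounds. Nothing shown here gives a reason for the large step.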